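Swapping a dichlorophenyl for a trifluoromethylphenyl

The source may report more compounds than this note shows. Statements on the series, on what has been measured and on what is new or still open speak of the compounds shown alone.

Compound 1, `O=C(O)c1cc(F)c2nc(N3CCC4(C=C(c5c(-c6c(Cl)cccc6Cl)noc5C5CC5)C4)CC3)sc2c1`, has been tested in an ADME assay on microsomes from liver (Mus musculus) for metabolic stability; on this read-out higher numbers stand for a longer-lived compound and lower numbers for a shorter-lived compound. In this assay, among the compounds with values here, compound 1 gives 2 h, which is the only plain number in the set. Compound 2, `O=C(O)c1cc(C(F)(F)F)c2cc(N3CCC4(C=C(c5c(-c6c(Cl)cncc6Cl)noc5C5CC5)C4)CC3)ccc2n1`, was run in the same assay. For compound 2 the result is > 2 h, and this is a limit of the assay rather than a number. Within the data shown here, as the limit of > 2 h in this assay, at which 1 of the 2 values shown sits, shows, one of the two readings sits at that limit, so no step between measured compounds can be counted here.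

Compound 3, `O=C(O)c1cc(F)c2nc(N3CCC4(C=C(c5c(-c6ccccc6C(F)(F)F)noc5C5CC5)C4)CC3)sc2c1`, is not yet measured. It differs from compound 1 in one place: 2-(trifluoromethyl)phenyl in place of 2,6-dichlorophenyl on an aromatic carbon. Both groups sit on the same aromatic carbon of the shared core, and both carry no hydrogen-bond donors or acceptors and no charge.

Among the measured compounds shown here, with no measured step to lean on, the expected step from compound 1 to compound 3 in this assay is no change at the digits printed from compound 1 to compound 3 (within the scatter), which is none beyond the usual scatter. Compound 3 is therefore estimated at 2 h, with a range from 1 h to 4 h.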

Compound 3, half-life: > 2 h
Compound 3: no number, only a limit (the forecaster's own chance of this, stated with the estimate: 40%); the middle value sits exactly at the limit.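

In this assay, 2-(trifluoromethyl)phenyl in place of 2,6-dichlorophenyl, on an aromatic carbon of a five-membered aromatic ring with 1 nitrogen and 1 oxygen, gives a number no lower from compound 1 to compound 3 (the limit leaves the size open). Compound 3 gives > 2 h, which is a limit of the assay and not a number. This is the only one-place comparison in the set, and it shows that on this read-out the two chlorine atoms of compound 1 can be given up at this position without a lower reading, though the size of the step cannot be read because of where the reading sits: the limit of > 2 h in this assay, at which 2 of the 3 values shown sit.

From the compounds shown here alone, how far compound 3 lies from compound 1 stays open, since only a number for compound 3 could settle it. The compounds shown also leave open what a plain phenyl, a 2-chlorophenyl or a 2-methoxyphenyl would give at this position on the shared core.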